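Macrophage cytotoxicity notes: aminopyrimidine series, compound 3 to 4

A few compounds are considered here, and "the series" means these few. Any claim that something is new, unique, unknown or untested is made for them only; others in the source may bear on it.

The set comprises compound 1 `CC1(c2ccc(NC(c3ccncc3)c3nnnn3C(C)(C)C)cc2)NC(=O)c2ccccc2N1`, compound 2 `CN1CCN(c2ccc(-c3cc(-c4ccc(C5NC(=O)c6ccccc6N5)cc4)nc(N)n3)cc2)CC1`, compound 3 `Nc1nc(-c2ccc(F)cc2)cc(-c2ccc(C3NC(=O)c4ccccc4N3)cc2)n1` and the yet unmeasured compound 4 `COc1cc(-c2cc(-c3ccc(C4NC(=O)c5ccccc5N4)cc3)nc(N)n2)cc(OC)c1OC`. The read-out under consideration is an ADME assay on J774.A1 cells (Mus musculus) for cytotoxicity, read by MTT assay, with a stated time of 72 h; on this read-out higher numbers stand for lower toxicity in this test and lower numbers for higher toxicity in this test. In this assay compound 2 gives 10200 nM. For compound 1 this assay gives "not determined" (no result reported). Compound 3 likewise gives "not determined" (no result reported) in this assay, so it stands without a measured anchor, and it is one of two entries in the set in that situation. Within the data shown here, no step between two measured compounds is available, so nothing about the size of a change in this assay can be read off directly.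

The move from compound 3 to compound 4 is 3,4,5-trimethoxyphenyl in place of 4-fluorophenyl on an aromatic carbon. The 4-fluorophenyl leaves and the 3,4,5-trimethoxyphenyl enters, on an aromatic carbon of the shared core.

Among the measured compounds shown here, with no measured starting point for compound 3, the only number to lean on is that of compound 2 in this assay, which sits in the low micromolar to tens-of-micromolar region, and the expected step for this change is small, not beyond the scatter in either direction. Compound 4 is therefore expected to give about 12000 nM in this assay, within a range of 3000 nM to 50000 nM.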

Compound 4, half-maximal cytotoxic concentration: 103000 nM
Compound 4: middle estimate off by 8.6-fold (0.93 log units), on the low side, and the stated range ends below it.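

In this assay, among these compounds, no step from compound 3 to compound 4 can be read; compound 3 has no single number to set against compound 4. The compounds shown leave open both the direction and the size of any change on replacing 4-fluorophenyl with 3,4,5-trimethoxyphenyl. Nothing at hand bears on the result for compound 4.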